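Removing the benzoyl group from compound 2

The compounds below may be only part of what the source reports. "The series", "measured", "known", "first", "only" and "open" are said of these compounds alone.

Compound 1 `CCCCCCCCCc1ccc(OP(=O)(O)OC[C@H]2O[C@@H](n3cc(F)c(=O)[nH]c3=O)C[C@@H]2OC(=O)c2ccccc2)cc1`: 20400 nM
Compound 2 `O=C(O[C@H]1C[C@H](n2cc(F)c(=O)[nH]c2=O)O[C@@H]1COP(=O)(O)Oc1ccc2ncccc2c1)c1ccccc1`: 2460 nM
Compound 3 `CCOC(=O)C[n+]1cccc2cc(OP(=O)([O-])OC[C@H]3O[C@@H](n4cc(F)c(=O)[nH]c4=O)C[C@@H]3OC(=O)c3ccccc3)ccc21`: 28900 nM

All three numbers come from a functional assay on Caco-2 cells (Homo sapiens) for cytotoxicity, read by MTT assay, with a stated time of 48 h; on this read-out higher numbers stand for weaker inhibition and lower numbers for stronger inhibition. Compound 2 stands lowest of the three at 2460 nM, and both compound 1 and compound 3 lie above it by more than the usual scatter. The three compounds all carry a benzoyl group, but they differ from one another elsewhere, so no single change can be read from their values.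

The next compound, compound 4 `O=c1[nH]c(=O)n([C@H]2C[C@H](O)[C@@H](COP(=O)(O)Oc3ccc4ncccc4c3)O2)cc1F`, has not yet been measured. It departs from compound 2 at one place, with hydrogen in place of benzoyl on an oxygen on a saturated carbon, so that benzoyloxy becomes hydroxy: hydrogen in place of benzoyl on an oxygen on a saturated carbon. Among the measured compounds shown here, no measured pair shows this change, which leaves its size without a direct guide. The only indication is the spread of the measured compounds, and compound 2 sits at its low end with 2460 nM. A moderate upward step in this assay, beyond the scatter but within that spread, is therefore expected. The expected change is a 2.4-fold higher number from compound 2 to compound 4 (0.39 log units; beyond the scatter). For compound 4 the estimated value is 6000 nM, with an expected range of 900 nM to 30000 nM.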

Compound 4, half-maximal inhibitory concentration: 1400 nM
Compound 4: the middle estimate sits 4.3-fold (0.63 log units) above what was measured; low and high end bracket the measured number.
By their numbers in this assay, from the lowest: compounds 4 and 2 (each within the scatter of the next); then compounds 1 and 3 (each within the scatter of the next).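

In this assay, taking away the benzoyl group, so that benzoyloxy becomes hydroxy on the oxygen on a saturated carbon, gives a 1.8-fold lower number from compound 2 to compound 4 (0.24 log units; within the scatter). Compounds 1, 2 and 3 all carried the benzoyl group, so they could say nothing about this position without it; this pair shows that, with the rest of compound 2 unchanged, the loss of all the benzoyl heavy atoms, including its aromatic ring, leaves the read-out within the usual scatter. For this one pair, then, the benzoyl group is not required to retain the level of cytotoxicity seen in compound 2, although the pair shows no gain from removing it, and nothing measured here offers a reason for this outcome.

What the compounds shown leave open is whether other groups on this oxygen, such as an acetyl group, a longer acyl chain or a carbamate bearing an amine, would also stay within the scatter of compound 2 and compound 4. They also leave open whether the same change from benzoyloxy to hydroxy would have a similarly small effect on compound 1 or compound 3, whose groups on the phosphate differ from that of compound 2.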